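Flipping One Stereocentre in an Antiproliferative Series

This account rests on a few compounds, and the source may have more. Where it says the series, first, only, none or still open, it means among the compounds named here.

Within the data shown here, in a functional assay on SK-MEL-28 cells (Homo sapiens) for antiproliferative activity (a higher number here means a weaker inhibitor, a lower number a stronger inhibitor), compound 3 `O=c1[nH]c(=O)n([C@@H]2C=C[C@@H](CO)O2)cc1F` gives 9800 nM, the only true number in this small set. Compound 1 `Nc1nc(=O)n([C@H]2C=C[C@@H](CO)O2)cc1Br` reports only a limit of the assay, > 100000 nM. Compound 2 `Nc1nc(=O)n([C@H]2C=C[C@@H](CO)O2)cc1I` also reports only a limit, > 100000 nM. Their step, a step that the two limits leave unreadable from compound 1 to compound 2, exchanges one halogen for another and has no readable size.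

Compound 4 `O=c1[nH]c(=O)n([C@@H]2C=C[C@H](CO)O2)cc1F` is related to compound 3 by the two compounds have the same atoms and bonds and differ only in configuration as drawn: 1 of 2 stereo elements differ; a stereocentre at a saturated ring carbon is drawn S in compound 3 and R in compound 4. Nothing leaves and nothing enters: a stereocentre at a saturated ring carbon is drawn S in compound 3 and R in compound 4.

Among the measured compounds shown here, no measured step here changes configuration, so none gives a size for this one. For the measured compounds named here, the only guide is the limit of > 100000 nM in this assay, at which 2 of the 3 values shown sit, which leans the expectation towards weaker activity, though not firmly. The expected change in this assay is a modest loss, a 2.0-fold higher number from compound 3 to compound 4 (0.31 log units; beyond the scatter), and this is only an estimate. For compound 4 the estimated value is 20000 nM, with an expected range of 5000 nM to 80000 nM.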

Compound 4, half-maximal inhibitory concentration: 7450 nM
Estimate against measurement, compound 4: 2.7-fold (0.43 log units) above; low and high end bracket the measured number.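

Redrawing this one stereocentre from S to R gives, in this assay, a 1.3-fold lower number from compound 3 to compound 4 (0.12 log units; within the scatter). With everything else in the molecule held the same, the drawn configuration at this saturated ring carbon makes no difference that can be told apart from the ordinary spread of repeated measurements, and the comparison isolates that single change: the fact that compounds 3 and 4 differ only in the configuration as drawn. Among these compounds, the only earlier step, between the bromo and iodo compounds, ran between two limits and cannot be read, so this is the first size in the set, and it belongs to this one pair alone.

Still open, from the compounds shown here alone, is whether the second stereo element can be changed just as freely. Equally open, going by these compounds, is whether a carboxylic acid in place of the hydroxymethyl group would keep the two configurations just as close.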